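This account rests on a few compounds, and the source may have more. Where it says the series, first, only, none or still open, it means among the compounds named here.

- compound 1 `Cc1cn(-c2csc(Nc3ccc(Br)cc3)n2)c(C)n1`: 400 nM
- compound 2 `Cc1nc2ccccc2n1-c1csc(Nc2cccc(Br)c2)n1`: 36000 nM

Among the measured compounds shown here, in a functional assay on RKO cells (Homo sapiens) for cytotoxicity, read by resazurin assay, with a stated time of 72 h (on this read-out lower numbers stand for stronger inhibition and higher numbers for weaker inhibition), compound 1 gives 400 nM, the lower of the two numbers measured so far. Compound 2 gives 36000 nM, which is far higher and beyond the usual scatter. The next compound to be tested is compound 3 `COc1ccc(Nc2nc(-n3cc(C)nc3C)cs2)cc1`, which keeps the core of compound 1 and changes one group. The difference is methoxy in place of bromo on an aromatic carbon, para to a large group.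

For the measured compounds named here, no pair of measured compounds shows what this kind of swap does, so the expectation is only a cautious one. In this assay, a modest step toward weaker inhibition is expected, with the estimate being a 2.5-fold higher number from compound 1 to compound 3 (0.40 log units; beyond the scatter). Going by the values given here, the range stays wide, as the only other measured compound, compound 2 at 36000 nM, shows how far numbers can spread among related structures. The expected value for compound 3 is 1000 nM, with an estimated range of 250 nM to 4000 nM.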

Compound 3, half-maximal inhibitory concentration: 250 nM
Beside the measured number, compound 3's estimate is 4.0-fold (0.60 log units) above it; the measured number falls inside the stated range.
By their numbers in this assay, from the lowest: compounds 3 and 1 (each within the scatter of the next); then compound 2.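

In this assay, putting methoxy in place of bromo on the aromatic carbon para to a large group gives a 1.6-fold lower number from compound 1 to compound 3 (0.20 log units; within the scatter) and so leaves the two compounds indistinguishable on this read-out. Among the compounds shown here, this is the first direct view of this position, since the earlier pair differed in more than one place, and it shows that a single bromine can give way to two heavy atoms, one of them an oxygen that adds a hydrogen-bond acceptor, without the number moving beyond the usual scatter. Why these two different groups give matching numbers remains unexplained, as no supporting measurement bears on the question.

Two groups at one position give only a narrow view of what that carbon accepts, so an amine, a carboxylic acid or a longer chain such as ethoxy could behave quite differently there. Compound 2 also remains unexplained, as it differs from compound 1 in more than one place and its much higher number cannot be tied to any single change.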